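Cyclopropyl in place of 2-methoxyphenyl on the amine

This account rests on a few compounds, and the source may have more. Where it says the series, first, only, none or still open, it means among the compounds named here.

For the measured compounds named here, in a functional assay on MGC-803 cells (Homo sapiens) for inhibition, read by sulforhodamine B assay (on this read-out higher numbers stand for weaker inhibition and lower numbers for stronger inhibition), compound 2 (`COc1ccccc1NC1=CC(=O)c2c(nc3n2[C@H]2OC[C@@H](O)[C@H]2OC3)C1=O`) gives 1670 nM as the only actual number so far. Compound 1 (`O=C1C(NC2CCCC2)=CC(=O)c2c1nc1n2[C@H]2OC[C@@H](O)[C@H]2OC1`) stands at > 16000 nM as a limit of the assay, not a number. Compound 3 (`O=C1C(NC2CC2)=CC(=O)c2c1nc1n2[C@H]2OC[C@@H](O)[C@H]2OC1`) has cyclopropyl in place of 2-methoxyphenyl on an amine nitrogen. Going by the values given here, the one measured step bearing on this is an at least 9.5-fold lower number from compound 1 to compound 2 (0.98 log units; beyond the scatter) with 2-methoxyphenyl in place of cyclopentyl. The change to cyclopropyl is expected to run the opposite way, with an estimated step of similar size (a 6.0-fold higher number from compound 2 to compound 3 (0.78 log units; beyond the scatter)) toward weaker inhibition in this assay here. For compound 3 the estimate is 10000 nM with an expected range from 3500 nM to 30000 nM overall.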

Compound 3, half-maximal inhibitory concentration: > 4000 nM
Compound 3 gave a limit, no number; the forecaster's own chance of this, stated with the estimate: 50%; the middle value lies beyond the limit too.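

In this assay, cyclopropyl in place of 2-methoxyphenyl on an amine nitrogen gives an at least 2.3-fold higher number from compound 2 to compound 3 (0.37 log units; beyond the scatter), so with cyclopentyl and cyclopropyl alike, inhibition stays weaker than with the 2-methoxyphenyl of compound 2. Compound 3 has a limit, not a number: the limit of > 4000 nM in this assay, at which 1 of the 3 values shown sits. The step between compound 1 and compound 3 cannot be read.

Still open, as far as these compounds go, is whether the stronger inhibition of compound 2 goes with the aromatic ring or with its methoxy group; plain phenyl on the same nitrogen would separate the two. From the compounds shown here alone, how weak compound 1 and compound 3 actually are also remains open.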